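This account rests on a few compounds, and the source may have more. Where it says the series, first, only, none or still open, it means among the compounds named here.

Of the compounds shown here, two in this set have been measured so far. In a functional assay on A549 cells (Homo sapiens) for antiproliferative activity, read by MTT assay, with a stated time of 72 h (a lower number here means a stronger inhibitor, a higher number a weaker inhibitor), compound 2, with the structure `CCCNC(=O)c1cc(Oc2ccc(NC(=O)c3cc4cccnc4n(-c4ccc(Br)cc4)c3=O)cc2)ccn1`, gives 150 nM, the lowest number of the two. Compound 1, with the structure `CCNC(=O)c1cc(Oc2ccc(NC(=O)c3cc4cccnc4n(-c4ccc(Br)cc4F)c3=O)cc2)ccn1`, gives 1820 nM in this assay; it differs from compound 2 in two places at once, so the gap between the two numbers, which lies beyond the usual scatter, cannot be tied to one change alone.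

Compound 3, with the structure `CCCNC(=O)c1cc(Oc2ccc(NC(=O)c3cc4cccnc4n(-c4ccc(Br)cc4F)c3=O)cc2)ccn1`, is not yet measured. It differs from compound 2 in a single place: fluoro in place of hydrogen on an aromatic carbon, which reads, cut one bond further out, as 4-bromophenyl turning into 4-bromo-2-fluorophenyl. Among the measured compounds shown here, no single-change step in this assay is known that would show what this exchange does on its own. A weakening of moderate size is expected for compound 3, because compound 1 carries the same fluoro and gives 1820 nM, though part of that gap may belong to its shorter amide chain. Compound 3 is therefore estimated at 400 nM, within a range of 150 nM to 1500 nM, a step from compound 2 to compound 3 of a 2.7-fold higher number from compound 2 to compound 3 (0.43 log units; beyond the scatter).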

Compound 3, half-maximal inhibitory concentration: 1310 nM
For compound 3 the middle estimate is 3.3-fold (0.52 log units) below the measured one; the measured number falls inside the stated range.
By their numbers in this assay, from the lowest: compound 2; then compounds 3 and 1 (each within the scatter of the next).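

In this assay, fluoro in place of hydrogen on an aromatic carbon, the exchange of 4-bromophenyl for 4-bromo-2-fluorophenyl, now has a step of its own: an 8.7-fold higher number from compound 2 to compound 3 (0.94 log units; beyond the scatter). This shows that this single atom, placed ortho to a large group and meta to the bromo group, is enough on its own to weaken the compound beyond the scatter. The second step, methyl in place of hydrogen on a saturated chain carbon, two bonds along the chain from an amide-type nitrogen, gives a 1.4-fold lower number from compound 1 to compound 3 (0.14 log units; within the scatter), so with the fluoro present the two chain lengths cannot be told apart in this assay, and no measurement at hand explains the effect of either exchange.

The compounds shown leave open whether the weakening is particular to fluoro or would also come with a chloro, methyl or methoxy group on that same aromatic carbon. They also leave open whether the amide chain matters when the fluoro is absent, and what a longer chain, such as butyl, or a chain ending in an amine would do.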